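The source may hold more compounds than are shown below. What is called first, only, known or untested is meant among the compounds shown, and "the series" means these compounds.

Compound 1 `CCC(CC)(c1nnc[nH]1)c1ccc(-c2ccc3cc(F)cc(F)c3c2)[nH]c1=O`: 1.09 h
Compound 2 `CCn1ncc2c(F)cc(-c3ccc(C(CC)(CC)c4nnc(C)[nH]4)c(=O)[nH]3)cc21`: > 3 h
Compound 3 `CC(C)C(c1ccc(-c2ccc3cccc(F)c3c2)[nH]c1=O)N1CCCCC1=O`: 0.0967 h

Compound 2 has the entry > 3 h, which is a limit of the assay and not a number. That leaves two true numbers in an ADME assay on microsomes from liver (Mus musculus) for metabolic stability; a lower number here means that the compound disappears faster, a higher number that the compound lasts longer. Compound 3 has the lower one at 0.0967 h. Compound 1 has the higher one at 1.09 h. That gap lies beyond the scatter.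

Compound 4 `CC(C)C(Cc1noc(=O)[nH]1)c1ccc(-c2ccc3cccc(F)c3c2)[nH]c1=O` is compound 3 with one group exchanged: a group of 7 heavy atoms (3 carbon, 2 nitrogen, 2 oxygen; one five-membered aromatic ring with 3 hetero atoms) in place of a group of 7 heavy atoms (5 carbon, 1 nitrogen, 1 oxygen; one six-membered non-aromatic ring with 1 hetero atom), on a saturated chain carbon bound to an aromatic carbon and a saturated chain carbon. The 2-oxopiperidin-1-yl group leaves, and a group with a five-membered aromatic ring takes its place.

Among the compounds with values here, no measured pair shows this exchange, so the expectation is a loose one. Compound 3 sits low at 0.0967 h, which leaves much more room to rise than to fall. The expected change is an upward step beyond the scatter, an 8.3-fold higher number from compound 3 to compound 4 (0.92 log units; beyond the scatter). For compound 4 the estimated half-life is 0.8 h, with an expected range of 0.25 h to 2.5 h.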

Compound 4, half-life: 2.78 h
Compound 4: middle estimate off by 3.5-fold (0.54 log units), on the low side; measured number above the stated range.
By their numbers in this assay, from the lowest: compound 3; then compound 1; then compound 4. At a limit, above all of these: compound 2.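

The exchange of 2-oxopiperidin-1-yl for the five-membered aromatic ring with 3 hetero atoms, on the saturated chain carbon, gives a 29-fold higher number from compound 3 to compound 4 (1.46 log units; beyond the scatter) in this assay. This is the first change in a single place among these compounds, and it shows that the group at this position alone can shift the half-life strongly, even with the same count of heavy atoms. One step cannot show which feature of the new group is responsible.

On these data alone, whether a carboxylic acid or an amine at this place would do the same stays open. How much higher the half-life can be read is also unclear, as compound 2 stands at a limit: the limit of > 3 h in this assay, at which 1 of the 4 values shown sits.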